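This account rests on a few compounds, and the source may have more. Where it says the series, first, only, none or still open, it means among the compounds named here.

Measured compounds:
- compound 1 `O=C1/C(=C/c2ccc(F)cc2)CN(S(=O)(=O)c2ccc(O[N+](=O)[O-])cc2)C/C1=C\c1ccc(F)cc1` gives 5000 nM in a functional assay on SMMC-7721 cells (Homo sapiens) for cytotoxicity, read by MTT assay, with a stated time of 24 h; on this read-out higher numbers stand for weaker inhibition and lower numbers for stronger inhibition
- compound 2 `O=C1/C(=C/c2ccc(F)cc2)CN(S(=O)(=O)c2ccc(Br)cc2)C/C1=C\c1ccc(F)cc1` gives 11500 nM
- compound 3 `N#Cc1ccc(S(=O)(=O)N2C/C(=C\c3ccc(F)cc3)C(=O)/C(=C/c3ccc(F)cc3)C2)cc1` gives 15000 nM

Compound 3 gives the largest of the three numbers. Its gap to compound 2 is within the scatter a 1.3-fold higher number from compound 2 to compound 3 (0.12 log units; within the scatter); its gap to compound 1 is beyond it a 3.0-fold higher number from compound 1 to compound 3 (0.48 log units; beyond the scatter). Compound 4 `CC(=O)Nc1ccc(S(=O)(=O)N2C/C(=C\c3ccc(F)cc3)C(=O)/C(=C/c3ccc(F)cc3)C2)cc1` differs from compound 3 in one place: acetamido in place of cyano on an aromatic carbon. Among the compounds with values here, no measured step exchanges cyano for acetamido. Within the data shown here, the steps that bear on it all swap the group on this aromatic carbon: the two steps away from nitrooxy, a 2.3-fold higher number from compound 1 to compound 2 (0.36 log units; beyond the scatter) and a 3.0-fold higher number from compound 1 to compound 3 (0.48 log units; beyond the scatter), were modest, and between bromo and cyano the number stayed within the scatter. The step of no change at the digits printed from compound 3 to compound 4 (within the scatter) is therefore expected to be small, with no clear direction. Compound 4 is estimated at 15000 nM in this assay, range 6000 nM to 40000 nM.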

Compound 4, half-maximal inhibitory concentration: 9800 nM
The estimate for compound 4 lay 1.5-fold (0.18 log units) above the measured number; the range from low to high includes it.
By their numbers in this assay, from the lowest: compounds 1, 4, 2 and 3 (each within the scatter of the next, the first and the last beyond it).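

In this assay, within the data shown here, acetamido, the only group here with a hydrogen-bond donor, stays within the scatter of cyano, with a 1.5-fold lower number from compound 3 to compound 4 (0.18 log units; within the scatter), and of bromo, with a 1.2-fold lower number from compound 2 to compound 4 (0.07 log units; within the scatter). It also stays within the scatter of nitrooxy, with a 2.0-fold higher number from compound 1 to compound 4 (0.29 log units; within the scatter), whereas bromo and cyano both lie beyond it. No supporting data explain these results.

As far as these compounds go, whether an amine or a carboxylic acid on this aromatic carbon would move the number beyond the scatter of these four compounds remains open. So does whether a longer acyl chain on the amide nitrogen would do so.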